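Swapping ethynyl for tert-butyl: an expected antiproliferative value

This account rests on a few compounds, and the source may have more. Where it says the series, first, only, none or still open, it means among the compounds named here.

Measured so far in a functional assay on SK-OV-3 cells (Homo sapiens) for antiproliferative activity, read by MTT assay, with a stated time of 72 h (on this read-out higher numbers stand for weaker inhibition and lower numbers for stronger inhibition), for these compounds:
Compound 1 `O=C(CCc1cccc2c1B(O)OC2)Nc1ccccc1` gives 200 nM
Compound 2 `C#Cc1ccc(NC(=O)CCc2cccc3c2B(O)OC3)cc1` gives 6300 nM

Of the two measured compounds, compound 2 (6300 nM) has the higher number and is the weaker inhibitor. The next compound, compound 3 `CC(C)(C)c1ccc(NC(=O)CCc2cccc3c2B(O)OC3)cc1`, keeps the shared core and changes one group: tert-butyl in place of ethynyl on an aromatic carbon is the difference, tert-butyl in place of ethynyl on an aromatic carbon. Within the data shown here, only one measured step bears on this change. It is a 32-fold higher number from compound 1 to compound 2 (1.50 log units; beyond the scatter), a large step beyond the scatter, in which ethynyl replaced hydrogen. Among the measured compounds shown here, no measured compound carries tert-butyl, so the data show nothing directly about that group. Compound 3 also carries a group other than hydrogen at this place, so it is expected to stay close to compound 2 (6300 nM) rather than return toward compound 1 (200 nM). The step expected in this assay is a 1.6-fold lower number from compound 2 to compound 3 (0.20 log units; within the scatter) and is expected to stay within the scatter. For compound 3 the estimated value is 4000 nM, with an expected range from 900 nM to 18000 nM on this estimate.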

Compound 3, half-maximal inhibitory concentration: 4200 nM
The estimate for compound 3 lay 1.1-fold (0.02 log units) below the measured number; the range from low to high includes it.
By their numbers in this assay, from the lowest: compound 1; then compounds 3 and 2 (each within the scatter of the next).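

With compound 3, a second group other than hydrogen stands at this place on the aromatic ring, para to a large group, and in this assay the change gives a 21-fold higher number from compound 1 to compound 3 (1.32 log units; beyond the scatter). The large step seen earlier is therefore not confined to ethynyl, and among these three compounds both groups carry a higher number than hydrogen, with no compound going against that pattern. Exchanging ethynyl for tert-butyl removes the triple bond and raises the count of heavy atoms, yet it gives only a 1.5-fold lower number from compound 2 to compound 3 (0.18 log units; within the scatter), so in this assay the two groups cannot be told apart. Nothing available here accounts for this result or for the gap to compound 1.

The compounds shown leave open whether any group at this place can keep a number close to that of compound 1, since only ethynyl and tert-butyl stand in for hydrogen, and a single fluorine atom or a methoxy group would test this with a smaller replacement. They also leave open how an amine or a carboxylic acid at the same place would read in this assay.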